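A few compounds are considered here, and "the series" means these few. Any claim that something is new, unique, unknown or untested is made for them only; others in the source may bear on it.

Measured compounds:

Compound 1 `COc1nc(N)nc2c1c(-c1ccccc1)cn2[C@@H]1O[C@H](CO)[C@@H](O)[C@H]1O` in an ADME assay on MRC5 cells (Homo sapiens), read by MTT assay, with a stated time of 72 h; on this read-out lower numbers stand for stronger inhibition and higher numbers for weaker inhibition: > 100000 nM, a limit of the assay.
Compound 2 `COc1ncnc2c1c(-c1ccccc1)cn2[C@@H]1O[C@H](CO)[C@@H](O)[C@H]1O`: > 100000 nM, a limit of the assay.
Compound 3 `O=c1[nH]cnc2c1c(-c1cc3ccccc3o1)cn2[C@@H]1O[C@H](CO)[C@@H](O)[C@H]1O`: > 100000 nM, a limit of the assay.

Compound 4 `Nc1nc2c(c(-c3cc4ccccc4o3)cn2[C@@H]2O[C@H](CO)[C@@H](O)[C@H]2O)c(=O)[nH]1` has not been measured in this assay.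

From compound 2 to compound 1 the change is amino in place of hydrogen on an aromatic carbon. The step that the two limits leave unreadable from compound 2 to compound 1 cannot be read, because the limit of > 100000 nM in this assay, at which 3 of the 3 values shown sit, holds both ends of it. The difference between the core of compound 3 and the core of compound 2 is not broken down here.

From compound 3 to compound 4 the change is amino in place of hydrogen on an aromatic carbon. This is the same kind of change as that from compound 2 to compound 1, though the surroundings differ: in compound 4 the entering amino is meta to a group of 1 heavy atom, in compound 1 meta to a methoxy group (2 heavy atoms).

Among the measured compounds shown here, with every value shown sitting at the limit, and the one earlier instance of this change unreadable, the expectation for compound 4 is that it also stays at the limit, since compound 3 gives > 100000 nM. The step expected from compound 3 to compound 4 is a number no higher from compound 3 to compound 4 (the limit leaves the size open). The estimate for compound 4 in this assay is 100000 nM, in the range 40000 nM to 400000 nM.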

Compound 4, half-maximal inhibitory concentration: > 100000 nM
Compound 4: no number, only a limit; the forecaster's own chance of this, stated with the estimate: 85%; the middle value lies on the limit itself.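

No new step can be read from compound 3 to compound 4, the amino in place of hydrogen on an aromatic carbon, as both ends of it are limits and not numbers: the limit of > 100000 nM in this assay, at which 4 of the 4 values shown sit.

The compounds shown leave open whether this amino changes the result in this assay at all, and how any of these compounds compare with one another.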